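A few compounds are considered here, and "the series" means these few. Any claim that something is new, unique, unknown or untested is made for them only; others in the source may bear on it.

Two compounds have been measured so far:
compound 1, `COc1ccc(C2OC(c3cc(OC)c(OC)c(OC)c3)=NN2C(C)=O)c(OC)c1` — 92%
compound 2, `COc1cc(/C=N/NC(=O)c2cc(OC)c(OC)c(OC)c2)cc(OC)c1OC` — 48.3%

In a functional assay on PC-3 cells (Homo sapiens) for antiproliferative activity, read by MTT assay, tested at 5 uM (a higher number here means a stronger effect of the compound at the concentration tested, a lower number a weaker effect), compound 1 gives 92%, and compound 2 gives 48.3%. For the measured compounds named here, compound 1 therefore stands highest of the two numbers, its only neighbour, compound 2, lying lower by a margin beyond the usual scatter. Going by the values given here, the two measured compounds are not linked by a single change, so no measured step is available to calibrate an exchange of one aryl group for another.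

Compound 3, `COc1cc(C2=NN(C(C)=O)C(c3ccc(C(F)(F)F)cc3)O2)cc(OC)c1OC`, is not yet measured. It differs from compound 1 in one place: 4-(trifluoromethyl)phenyl in place of 2,4-dimethoxyphenyl on a saturated ring carbon. Among the compounds with values here, with no measured pair to set the size of such an exchange, the expectation rests on compound 1 alone. Compound 3 is expected to give 75%, within a range from 45% to 95%. This estimate corresponds to an expected step of a number 17 percentage points lower from compound 1 to compound 3 (beyond the scatter), a modest decrease that may or may not exceed the scatter.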

Compound 3, a percentage reported as inhibition, at one concentration (the size of the read-out at that concentration, not a potency): -0.7%
For compound 3 the middle estimate is 75.7 percentage points above the measured one, and the stated range ends above it.
By their numbers in this assay, from the lowest: compound 3; then compound 2; then compound 1.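

For the compounds shown here, replacing 2,4-dimethoxyphenyl with 4-(trifluoromethyl)phenyl on the saturated ring carbon gives the first measured exchange at this position, and in this assay it brings a number 92.7 percentage points lower from compound 1 to compound 3 (beyond the scatter). The rest of the structure stays the same, yet compound 3 gives only -0.7%, so the effect seen with compound 1 at the concentration tested does not survive this single change. Nothing available explains why this exchange has such an outcome.

The compounds shown leave open whether the step follows from the departure of the two methoxy groups, the arrival of the trifluoromethyl group, or both. As far as these compounds go, a plain phenyl or a 4-methoxyphenyl at this position would help separate these possibilities, and the effect of a 4-chlorophenyl also remains open.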